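Removing a Methyl from a Nitrophenyl Dienone

A few compounds are considered here, and "the series" means these few. Any claim that something is new, unique, unknown or untested is made for them only; others in the source may bear on it.

Compound 1 `O=C1/C(=C/c2ccccc2)CCC/C1=C\c1cccc([N+](=O)[O-])c1`: 1700 nM
Compound 2 `Cc1ccc(/C=C2\CCC/C(=C\c3ccccc3[N+](=O)[O-])C2=O)cc1`: 7520 nM

Both compounds were tested in a functional assay on MOLT-4 cells (Homo sapiens) for cytotoxicity, with a stated time of 72 h; a higher number here means a weaker inhibitor, a lower number a stronger inhibitor. Compound 2 stands at the highest of the two numbers; its nearest neighbour, compound 1, shows a lower value, and that gap lies beyond the usual scatter. Compound 3 `O=C1/C(=C/c2ccccc2)CCC/C1=C\c1ccccc1[N+](=O)[O-]` differs from compound 2 in one place: hydrogen in place of methyl on an aromatic carbon. Going by the values given here, no measured pair isolates this change, so its effect is unknown. Only a small shift, in either direction, or none beyond the scatter is expected. Compound 3 is estimated to give 4500 nM in this assay, within a range from 1800 nM to 11000 nM. The expected step is a 1.7-fold lower number from compound 2 to compound 3 (0.22 log units; within the scatter).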

Compound 3, half-maximal inhibitory concentration: 1480 nM
The estimate for compound 3 lay 3.0-fold (0.48 log units) above the measured number, and the stated range ends above it.
By their numbers in this assay, from the lowest: compounds 3 and 1 (each within the scatter of the next); then compound 2.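

Going from 4-methylphenyl to phenyl in this assay gives a 5.1-fold lower number from compound 2 to compound 3 (0.71 log units; beyond the scatter), a step beyond the usual scatter. This position is therefore not indifferent: one methyl on the aromatic carbon is enough to move the number, and the hydrogen carries the lower one. Nothing available explains this shift. The compounds shown leave open whether a chlorine, a methoxy group or an amine at this place would sit nearer compound 2 or compound 3. As far as these compounds go, whether adding the same methyl to compound 1 would raise its number is also open.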